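The compounds below may be only part of what the source reports. "The series", "measured", "known", "first", "only" and "open" are said of these compounds alone.

Values in a functional assay on L02 cells (Homo sapiens) for inhibition, read by Griess assay, with stated times of 1 h and 24 h; a higher number here means a weaker inhibitor, a lower number a stronger inhibitor:

Compound 1 `COc1cc(/C=C/c2nc(Nc3ccc(C(C)C)cc3)c3sccc3n2)cc(OC)c1OC`: 370000 nM
Compound 2 `COc1cc(/C=C/c2nc(N(C)c3ccccc3)c3sccc3n2)cc(OC)c1OC`: 767000 nM
Compound 3 `COc1cc(/C=C/c2nc(NCc3ccccc3)c3sccc3n2)cc(OC)c1OC`: > 1000000 nM

For compound 3 the figure the limit of > 1000000 nM in this assay, at which 1 of the 3 values shown sits, is a limit of the assay, not a number. On the shared core, compound 3 therefore stands at or past the weak end of the three measured values.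

Compound 4 `COc1cc(/C=C/c2nc(NCc3ccc(Cl)cc3)c3sccc3n2)cc(OC)c1OC` differs from compound 3 by chloro in place of hydrogen on an aromatic carbon. The measured steps that lead to compound 3 are an at least 2.7-fold higher number from compound 1 to compound 3 (0.43 log units; beyond the scatter) and an at least 1.3-fold higher number from compound 2 to compound 3 (0.11 log units; that floor lies within the scatter); both alter the group on the ring nitrogen, and neither tests a chloro on the benzyl ring. Going by the values given here, with no measured step on this position, no step beyond the scatter is expected, so a step that the limit leaves unreadable from compound 3 to compound 4 is the estimated change. Compound 4 is expected at 1500000 nM, range 500000 nM to 5000000 nM, most likely reported again as a limit.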

Compound 4, half-maximal inhibitory concentration: > 1000000 nM
Compound 4: only a limit was reported; the forecaster's own chance of this, stated with the estimate: 75%; the middle value lies beyond the limit too.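

In this assay, chloro in place of hydrogen on the benzyl ring does not bring compound 4 inside the measurable range; its value is a limit, and the step from compound 3 to compound 4 cannot be read: the limit of > 1000000 nM in this assay, at which 2 of the 4 values shown sit.

4-Chlorobenzyl in place of 4-isopropylphenyl gives an at least 2.7-fold higher number from compound 1 to compound 4 (0.43 log units; beyond the scatter), whereas (4-chlorobenzyl)amino in place of methyl(phenyl)amino gives an at least 1.3-fold higher number from compound 2 to compound 4 (0.11 log units; that floor lies within the scatter).

On these data alone, whether any group on the benzyl ring can lift the benzylamino compounds off the limit stays open. A methoxy, an amine or a carboxylic acid on that ring would test this.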